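Methyl in Place of Phenyl: Expectation for Compound 4

The source may hold more compounds than are shown below. What is called first, only, known or untested is meant among the compounds shown, and "the series" means these compounds.

Compound 1 `C/C1=C\CC[C@@]2(C)O[C@@H]2C(=O)[C@@H]2CC[C@@H](C)[C@](C)(CC1)[C@H]2CO` gives 1300 nM in an assay (Oryctolagus cuniculus) for inhibition of platelet-activating factor receptor (Cavia porcellus); on this read-out lower numbers stand for stronger inhibition and higher numbers for weaker inhibition.
Compound 2 `CC(=O)OC[C@H]1[C@H]2CC[C@@H](C)[C@]1(C)CC/C(C)=C/CC[C@@]1(C)O[C@@H]1C2=O` gives 410 nM in this assay.
Compound 3 `C/C1=C\CC[C@@]2(C)O[C@@H]2C(=O)[C@@H]2CC[C@@H](C)[C@](C)(CC1)[C@H]2COC(=O)Oc1ccccc1` gives 550 nM in this assay.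

Compound 3 stands second highest of these three numbers; compound 2 is near it, and compound 1 is further off. Compound 4 `COC(=O)OC[C@H]1[C@H]2CC[C@@H](C)[C@]1(C)CC/C(C)=C/CC[C@@]1(C)O[C@@H]1C2=O` differs from compound 3 by methyl in place of phenyl on an oxygen next to a carbonyl group. Going by the values given here, no measured step alters this part of the molecule in the same way. The nearest guide is a 1.3-fold higher number from compound 2 to compound 3 (0.13 log units; within the scatter), which shows that exchanging the group on the carbonyl carbon hardly moves the number, whereas a 3.2-fold lower number from compound 1 to compound 2 (0.50 log units; beyond the scatter) and a 2.4-fold lower number from compound 1 to compound 3 (0.37 log units; beyond the scatter) show that placing such a group on the oxygen on the saturated carbon helps modestly. Compound 4 keeps that group, so compound 4 is expected to show a 1.1-fold lower number from compound 3 to compound 4 (0.04 log units; within the scatter), a step within the scatter. Compound 4 is estimated at 500 nM, within 250 nM to 1000 nM.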

Compound 4, half-maximal inhibitory concentration: 26 nM
Compound 4: middle estimate off by 19-fold (1.28 log units), on the high side, and the stated range ends above it.
By their numbers in this assay, from the lowest: compound 4; then compounds 2 and 3 (each within the scatter of the next); then compound 1.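

In this assay, going by these compounds alone, the group on this oxygen matters far more than the earlier compounds suggested: methyl in place of phenyl gives a 21-fold lower number from compound 3 to compound 4 (1.33 log units; beyond the scatter) and methoxy in place of methyl on the carbonyl carbon gives a 16-fold lower number from compound 2 to compound 4 (1.20 log units; beyond the scatter) even though compound 2 and compound 3 lie within the scatter of each other. Methoxycarbonyl in place of hydrogen gives a 50-fold lower number from compound 1 to compound 4 (1.70 log units; beyond the scatter) so the gain depends on which group is added, not merely on adding one. No evidence here explains this jump.

From the compounds shown here alone, whether the low number is special to methyl stays open. Ethyl or a longer chain on this oxygen, or an amine in place of methoxy, could keep it or lose it.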